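Fluoro for acetyl on a urea series: ortho versus meta

The source may hold more compounds than are shown below. What is called first, only, known or untested is meant among the compounds shown, and "the series" means these compounds.

Of the compounds shown here, three have been measured in an ADME assay on the whole organism with Oryza sativa as the target, tested at 10 uM; a higher number here means a weaker effect of the compound at the concentration tested, a lower number a stronger effect. Compound 1 `CC(=O)c1ccccc1NC(=O)N[C@H](C)c1ccccc1` gives 89% in this assay. Compound 2 `CC(=O)c1cccc(NC(=O)N[C@H](C)c2ccccc2)c1` gives 73% in the same assay; compound 1 and compound 2 share the same atoms joined differently, and the difference between the two cores is not broken down here. Compound 3 `C[C@@H](NC(=O)Nc1ccccc1F)c1ccccc1` gives 77%, which sits within the scatter of compound 2.

One change is shown directly: fluoro in place of acetyl on an aromatic carbon. This change produced a number 12 percentage points lower from compound 1 to compound 3 (beyond the scatter).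

Compound 4 `C[C@@H](NC(=O)Nc1cccc(F)c1)c1ccccc1` has not yet been measured. It arises from compound 2 by the same kind of change: fluoro in place of acetyl on an aromatic carbon. The two changes differ in their surroundings, one being ortho to a large group and the other meta to a large group, so the effect seen in one case need not repeat exactly. Among the measured compounds shown here, still, because the only measured example gave a number 12 percentage points lower from compound 1 to compound 3 (beyond the scatter), a step of similar direction is expected, namely a number 8 percentage points lower from compound 2 to compound 4 (within the scatter). On that basis, compound 4 is estimated to give 65%, within a range from 50% to 82%.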

Compound 4, a percentage reported as activity, at one concentration (the size of the read-out at that concentration, not a potency): 84%
Estimate against measurement, compound 4: 19 percentage points below, and the stated range ends below it.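

The same swap did not carry over between the two cores: in this assay, fluoro in place of acetyl gave a number 11 percentage points higher from compound 2 to compound 4 (beyond the scatter), so the direction seen on the core of compound 1 did not repeat on the core of compound 2. Set side by side, the two steps differ by more than repeat measurements would explain, and their directions are opposite: the same change on two cores in this assay, a number 12 percentage points lower (beyond the scatter) from compound 1 to compound 3 and a number 11 percentage points higher (beyond the scatter) from compound 2 to compound 4, 23 percentage points apart, beyond the scatter of two such steps. Among the compounds shown here, this shows that the effect of the swap depends on the core it is made on, so a result from one core is a poor guide to the other, but with only one pair per core it does not show why the steps part or which direction would hold on a further core.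

As far as these compounds go, it remains open whether a chloro group, a methoxy group or an amine in place of acetyl would move the number the same way on both cores or would split as fluoro does. Also open, from the compounds shown here alone, is whether the place of the group on the ring accounts for the split, a question that two pairs cannot settle.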